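The source may hold more compounds than are shown below. What is called first, only, known or untested is meant among the compounds shown, and "the series" means these compounds.

Compound 2, with the structure `COc1ccc2nc(C)cc(OCC(=O)NCCCc3ccccc3)c2c1`, was examined in an ADME assay on HepG2 cells (Homo sapiens) for cytotoxicity, read by trypan blue exclusion, with a stated time of 48 h, in the presence of a further agent that is not named here (on this read-out higher numbers stand for lower toxicity in this test and lower numbers for higher toxicity in this test), and there compound 2 gives > 137000 nM, which is a limit of the assay rather than a measured number. Going by the values given here, the one comparison compound, compound 1 with the structure `COc1ccc2nc(C)cc(OCC(=O)Nc3ccc(C)cc3)c2c1`, likewise gives only a limit in this assay, namely > 149000 nM. Among the compounds with values here, the single change between them, a step that the two limits leave unreadable from compound 1 to compound 2, therefore cannot be sized, since both ends rest on limits: the limit of > 137000 nM in this assay, at which 1 of the 2 values shown sits, and the limit of > 149000 nM in this assay, at which 1 of the 2 values shown sits, are all that the two values show.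

Compound 3, with the structure `COCCNC(=O)COc1cc(C)nc2ccc(OC)cc12`, is not yet measured. It differs from compound 2 by methoxy in place of benzyl on a saturated chain carbon, two bonds along the chain from an amide-type nitrogen. Within the data shown here, no readable step bears on this change; the only measured step is the unreadable one above. Compound 3 is therefore expected to remain at the limit as well, the expected step being a step that the limit leaves unreadable from compound 2 to compound 3. The estimate for compound 3 is 150000 nM, within a range of 50000 nM to 400000 nM.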

Compound 3, half-maximal cytotoxic concentration: > 164000 nM
Compound 3: no number, only a limit; the forecaster's own chance of this, stated with the estimate: 85%; middle value at least 1.0-fold (0.03 log units) from the limit.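

In this assay compound 3 gives > 164000 nM, again a limit of the assay and not a number. Its steps from compound 2 and compound 1 cannot be read. The compounds shown leave open whether changing the group on the amide-type nitrogen alters the read-out of this assay at all.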